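Three Analogues in a Cell Cytotoxicity Test

The compounds below may be only part of what the source reports. "The series", "measured", "known", "first", "only" and "open" are said of these compounds alone.

Compound 1 `COc1ccc2c(c1)c(/C=C1/C(=O)Nc3ccc(F)cc31)cn2Cc1cn([C@@H]2O[C@H](COC(C)=O)[C@@H](OC(C)=O)[C@H](OC(C)=O)[C@H]2OC(C)=O)nn1` and compound 2 `COc1ccc(/C=C2\C(=O)N(Cc3cn([C@@H]4O[C@H](COC(C)=O)[C@@H](OC(C)=O)[C@H](OC(C)=O)[C@H]4OC(C)=O)nn3)c3ccccc32)cc1OC` share a common core and were both examined in an ADME assay on NIH3T3 cells (Homo sapiens) for cytotoxicity, read by sulforhodamine B assay, with a stated time of 48 h; on this read-out lower numbers stand for stronger inhibition and higher numbers for weaker inhibition. Compound 1 gives > 200000 nM, which is a limit of the assay rather than a number. Compound 2 gives > 100000 nM, again a limit and not a measured value. One of the two values shown sits at the limit of > 200000 nM in this assay, at which 1 of the 2 values shown sits. The other sits at the limit of > 100000 nM in this assay, at which 1 of the 2 values shown sits. For the measured compounds named here, compound 2 therefore stands where nothing can be ordered: both compounds lie at limits, and no step between them can be counted.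

Compound 3 `CC(=O)OC[C@H]1O[C@@H](n2cc(CN3C(=O)/C(=C\c4ccc5ccccc5c4)c4ccccc43)nn2)[C@H](OC(C)=O)[C@@H](OC(C)=O)[C@@H]1OC(C)=O` differs from compound 2 by naphthalen-2-yl in place of 3,4-dimethoxyphenyl on a double-bonded chain carbon bound to a double-bonded ring carbon, a change that leaves the rest of the molecule untouched. Going by the values given here, no measured pair shows what this exchange does in this assay. The step from compound 2 to compound 3 is expected to be a step that the limit leaves unreadable from compound 2 to compound 3, which means no shift beyond the usual scatter in either direction. Compound 3 is accordingly estimated at 120000 nM in this assay, with a range from 30000 nM to 400000 nM, and it is expected that the assay would most likely again report only a limit.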

Compound 3, half-maximal inhibitory concentration: 80000 nM
Compound 3: middle estimate off by 1.5-fold (0.18 log units), on the high side, and the stated range covers the measured number.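

For the compounds shown here, compound 3 is the only compound here to give a number rather than a limit, so the exchange of 3,4-dimethoxyphenyl for naphthalen-2-yl on a double-bonded chain carbon bound to a double-bonded ring carbon can now be read in one direction in this assay, as an at least 1.2-fold lower number from compound 2 to compound 3 (0.09 log units; that floor lies within the scatter). That step is only a floor and not a full size, because compound 2 stands at a limit and not at a number: the limit of > 100000 nM in this assay, at which 1 of the 3 values shown sits. The floor alone does not establish a real shift at this place, even though the exchange swaps one six-membered aromatic ring of carbon only, carrying 2 hydrogen-bond acceptors, for 2 such rings with none.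

Going by these compounds, the true size of the step remains open, since the reading for compound 2 has no upper end. Going by these compounds alone, also open is whether a different group at this place, such as an amine or a carboxylic acid on the aromatic ring, would give a number in this assay that stands clearly apart from the one for compound 3.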